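A Methoxy Step from Compound 3 to Compound 4

The source may report more compounds than this note shows. Statements on the series, on what has been measured and on what is new or still open speak of the compounds shown alone.

Compound 1 `COc1cc(/C=N/Nc2nc(-c3cccc(Br)c3)cs2)cc(Br)c1OC`: 86300 nM
Compound 2 `COc1ccccc1-c1csc(N/N=C/c2cc(OC)c(OC)c(Br)c2Br)n1`: > 100000 nM (a limit, not a number)
Compound 3 `COc1cc(/C=N/Nc2nc(-c3ccccc3)cs2)cc(Br)c1OC`: 74100 nM

In a functional assay on U-87MG ATCC cells for inhibition, with U-87 MG (Homo sapiens) as the target, read by MTT assay, with a stated time of 48 h (a higher number here means a weaker inhibitor, a lower number a stronger inhibitor), compound 3 gives 74100 nM, and compound 1 lies within the scatter of it at 86300 nM. For compound 2 the assay reports > 100000 nM, which is a limit of the assay and not a number.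

The next compound to be tested is compound 4 `COc1ccccc1-c1csc(N/N=C/c2cc(Br)c(OC)c(OC)c2)n1`. It differs from compound 3 by methoxy in place of hydrogen on an aromatic carbon, ortho to a large group, so that phenyl becomes 2-methoxyphenyl (methoxy in place of hydrogen on an aromatic carbon).

Among the compounds with values here, no measured step makes this exact change. Within the data shown here, the one measured step on the same ring is a 1.2-fold lower number from compound 1 to compound 3 (0.07 log units; within the scatter), with hydrogen in place of bromo, and it stays within the scatter. Among the measured compounds shown here, compound 2 also carries 2-methoxyphenyl but differs elsewhere, and its limit of > 100000 nM gives no size of step. It does hint that any drift would run toward a higher number.

No step beyond the scatter is therefore expected in this assay. The estimate amounts to an expected 1.2-fold higher number from compound 3 to compound 4 (0.08 log units; within the scatter). For compound 4 the estimated value is 90000 nM, with an expected range of 50000 nM to 160000 nM.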

Compound 4, half-maximal inhibitory concentration: > 100000 nM
Compound 4 ended at the assay's limit (the forecaster's own chance of this, stated with the estimate: 35%); middle value at least 1.1-fold (0.04 log units) away from the limit.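

In this assay, methoxy in place of hydrogen on an aromatic carbon, ortho to a large group, gives an at least 1.3-fold higher number from compound 3 to compound 4 (0.13 log units; that floor lies within the scatter). Within the data shown here, this is the first direct reading of the change at this position, but it fixes only a floor, so the result gives no true size for the step and does not show it to lie beyond the scatter. Setting 2-methoxyphenyl in place of 3-bromophenyl gives an at least 1.1-fold higher number from compound 1 to compound 4 (0.06 log units; that floor lies within the scatter), again only a floor, and compound 4 now joins compound 2 at the same limit of the assay, which is not a number, so the step between those two cannot be read: the limit of > 100000 nM in this assay, at which 2 of the 4 values shown sit.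

As far as these compounds go, how far methoxy at this position really moves the number stays open, since compound 4 provides only a limit and the step from compound 3 could be small or large. From the compounds shown here alone, whether a hydroxyl or an amine on the same aromatic carbon would give a readable value in this assay, and so a measured size for a change at this position, also stays open.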